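Cinnamate esters of an arylidene-cyclohexanone: chloro for bromo step

The source may report more compounds than this note shows. Statements on the series, on what has been measured and on what is new or still open speak of the compounds shown alone.

Measured so far in a functional assay on MOLT-4 cells (Homo sapiens); a lower number here means a stronger inhibitor, a higher number a weaker inhibitor:
compound 1 `O=C(/C=C/c1ccc(Br)cc1)Oc1ccc(/C=C2\CCCCC2=O)cc1` gives 180000 nM
compound 2 `O=C(/C=C/c1ccc(Cl)c(Cl)c1)Oc1ccc(/C=C2\CCCCC2=O)cc1` gives 47300 nM
compound 3 `CN(C)CC1CCC/C(=C\c2ccc(OC(=O)/C=C/c3ccc(Br)cc3)cc2)C1=O` gives 3060 nM

Compound 2 differs from compound 1 by 3,4-dichlorophenyl in place of 4-bromophenyl on a double-bonded chain carbon bound to a double-bonded chain carbon, and the step is a 3.8-fold lower number from compound 1 to compound 2 (0.58 log units; beyond the scatter). Compound 3 differs from compound 1 by (dimethylamino)methyl in place of hydrogen on a saturated ring carbon, with the step of a 59-fold lower number from compound 1 to compound 3 (1.77 log units; beyond the scatter); compound 3 has the lowest number of the three.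

Compound 4 `CN(C)CC1CCC/C(=C\c2ccc(OC(=O)/C=C/c3ccc(Cl)c(Cl)c3)cc2)C1=O` is not yet measured. It differs from compound 3 by 3,4-dichlorophenyl in place of 4-bromophenyl on a double-bonded chain carbon bound to a double-bonded chain carbon, the same change that took compound 1 to compound 2, made on the core of compound 3.

Expected: the step is estimated as a 3.4-fold lower number from compound 3 to compound 4 (0.53 log units; beyond the scatter), resting on compound 1 to compound 2 where the same change gave a 3.8-fold lower number from compound 1 to compound 2 (0.58 log units; beyond the scatter), and on compound 3 at 3060 nM. For compound 4 in this assay the estimate is 900 nM, expected between 300 nM and 3000 nM.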

Compound 4, half-maximal inhibitory concentration: 4570 nM
Compound 4: middle estimate off by 5.1-fold (0.71 log units), on the low side; the measured number lies above the stated range.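

In this assay the exchange of 4-bromophenyl for 3,4-dichlorophenyl gives a 1.5-fold higher number from compound 3 to compound 4 (0.17 log units; within the scatter) and so does not repeat on the core of compound 3 what it did on the core of compound 1: the same change on two cores in this assay, a 3.8-fold lower number (0.58 log units; beyond the scatter) from compound 1 to compound 2 and a 1.5-fold higher number (0.17 log units; within the scatter) from compound 3 to compound 4, 5.7-fold (0.75 log units) apart, beyond the scatter of two such steps.

The (dimethylamino)methyl group still gives a 10-fold lower number from compound 2 to compound 4 (1.01 log units; beyond the scatter) on the 3,4-dichlorophenyl side, but this step too differs from its counterpart on the 4-bromophenyl side: the same change on two cores in this assay, a 59-fold lower number (1.77 log units; beyond the scatter) from compound 1 to compound 3 and a 10-fold lower number (1.01 log units; beyond the scatter) from compound 2 to compound 4, 5.7-fold (0.75 log units) apart, beyond the scatter of two such steps.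

The two changes are therefore not additive across these four compounds, though this single set of four shows neither why nor whether the same holds for other aryl groups.

Open, from the compounds shown here alone, is whether 4-chlorophenyl or 4-methoxyphenyl would depend on the core in the same way. Also open, going by these compounds, is whether a piperidine or morpholine in place of the dimethylamino group would keep the large step.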